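Working notes on cytotoxicity, compound 2 toward compound 4

The compounds below may be only part of what the source reports. "The series", "measured", "known", "first", "only" and "open" are said of these compounds alone.

Measured so far in an ADME assay on NIH3T3 cells (Mus musculus) for cytotoxicity, with a stated time of 72 h; on this read-out higher numbers stand for weaker inhibition and lower numbers for stronger inhibition:
- compound 1 `OC[C@H]1O[C@@H](n2cnc3c(NCc4ccccc4Cl)ncnc32)[C@H](O)[C@@H]1O`: a limit of the assay, > 166000 nM.
- compound 2 `OC[C@H]1O[C@@H](n2cnc3c(NCc4cccc(Br)c4)ncnc32)[C@H](O)[C@@H]1O`: a limit of the assay, > 166000 nM.
- compound 3 `OC[C@H]1O[C@@H](n2cnc3c(NCc4ccc(Cl)cc4Cl)ncnc32)[C@H](O)[C@@H]1O`: "not determined" (no result reported), no result reported.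

Compound 2 stands only at a limit in this assay; one further value is also a limit, and one further entry has no single number. The step from compound 1 to compound 2, a step that the two limits leave unreadable from compound 1 to compound 2, cannot be read from the two limits. Compound 4 `COc1cccc(CNc2ncnc3c2ncn3[C@@H]2O[C@H](CO)[C@@H](O)[C@H]2O)c1O` differs from compound 2 by 2-hydroxy-3-methoxyphenyl in place of 3-bromophenyl on a saturated chain carbon bound to a nitrogen on an aromatic ring. Within the data shown here, no measured step bears readably on this change; the only evidence at hand is the limit of > 166000 nM in this assay, at which 2 of the 3 values shown sit. For compound 4 no step beyond the scatter is therefore expected, a step that the limit leaves unreadable from compound 2 to compound 4. Compound 4 is expected to give 200000 nM, within a range from 100000 nM to 500000 nM, most probably reported again as a limit in this assay.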

Compound 4, half-maximal inhibitory concentration: > 166000 nM
Compound 4: only a limit was reported; the forecaster's own chance of this, stated with the estimate: 85%; the middle value lies beyond the limit too.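

In this assay compound 4 stands at the limit > 166000 nM and gives no number. Among these compounds, no new step can therefore be read among compound 1, compound 2 and compound 4. The compounds shown leave open whether any change at this place alters cytotoxicity.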